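The source may report more compounds than this note shows. Statements on the series, on what has been measured and on what is new or still open speak of the compounds shown alone.

Working notes on the series. In a functional assay on MCF7 cells (Homo sapiens) for antiproliferative activity, read by MTT assay, with a stated time of 48 h (a lower number here means a stronger inhibitor, a higher number a weaker inhibitor), compound 1 `O=C(/C=C/c1ccc2c(c1)OCCCO2)NS(=O)(=O)c1ccccc1` gives 53.9 ug/mL. Compound 2 `O=C(/C=C/c1ccc2c(c1)OCCCO2)NS(=O)(=O)c1ccc(Cl)cc1` gives > 100 ug/mL, which is a limit of the assay and not a number. Its position is known only through (the limit of > 100 ug/mL in this assay, at which 1 of the 2 values shown sits).

Compound 3 `O=C(/C=C/c1ccc2c(c1)OCCCO2)NS(=O)(=O)c1ccc(Br)cc1` differs from compound 2 by bromo in place of chloro on an aromatic carbon, para to a large group.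

For the measured compounds named here, one measured step bears on this change: an at least 1.8-fold higher number from compound 1 to compound 2 (0.26 log units; that floor lies within the scatter), with chloro in place of hydrogen on an aromatic carbon. That step is only a floor, and it does not compare bromo with chloro. With only an at least 1.8-fold higher number from compound 1 to compound 2 (0.26 log units; that floor lies within the scatter) to go on, no step beyond the scatter is expected in this assay, in either direction. A report of compound 3 as a limit, rather than a number, is also expected to be the more likely outcome.

The expected step is a number no higher from compound 2 to compound 3 (the limit leaves the size open). For compound 3 the estimated value is 100 ug/mL, with an expected range from 50 ug/mL to 200 ug/mL.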

Compound 3, half-maximal inhibitory concentration: > 100 ug/mL
Compound 3 gave a limit, no number; the forecaster's own chance of this, stated with the estimate: 65%; the middle value lies on the limit itself.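

In this assay compound 3 also gives a limit and not a number, as compound 2 does, so the change from 4-chlorophenyl to 4-bromophenyl cannot be read, and neither can any order between the two halogens: the limit of > 100 ug/mL in this assay, at which 2 of the 3 values shown sit.

The move from hydrogen to bromo now has its own reading, an at least 1.8-fold higher number from compound 1 to compound 3 (0.26 log units; that floor lies within the scatter), and this is again only a floor. Of the three compounds shown, only compound 1, with hydrogen at this position, gives a number, and neither halogen para to a large group does.

Still open, going by these compounds, is whether a different group in this place, such as an amine, a methoxy group or a carboxylic acid, would give a number in this assay, and how that number would stand against compound 1 at 53.9 ug/mL. On these data alone, the true size of the steps from hydrogen to chloro and from hydrogen to bromo also remains open.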